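A few compounds are considered here, and "the series" means these few. Any claim that something is new, unique, unknown or untested is made for them only; others in the source may bear on it.

All three measured compounds share one core. Compound 1 `COc1ccc(NC(=O)Oc2cc(=O)n(CCCO)c3c2CC(CC=C(C)C)C(C)(C)C3)cc1` gives 3.7% in a functional assay on PANC-1 cells (Homo sapiens) for inhibition, read by MTT assay, with a stated time of 24 h, tested at 10 uM; a lower number here means less inhibition, a higher number more inhibition at the concentration tested (going by the name of the read-out). Compound 2 `CC(C)=CCC/C(C)=C/CC1Cc2c(OCC=C(C)C)cc(=O)n(CCCO)c2CC1(C)C` gives 30.3% in this assay. Compound 3 `COc1ccc(NC(=O)Oc2cc(=O)n(CCCO)c3c2CC(C/C=C(\C)CCC=C(C)C)C(C)(C)C3)cc1` gives 64.1% in this assay, the highest of the three numbers, standing above compound 2 and still further above compound 1. The step of a number 60.4 percentage points higher from compound 1 to compound 3 (beyond the scatter) came with 3-methylbut-2-en-1-yl in place of hydrogen on a saturated chain carbon bound to a double-bonded chain carbon. The step of a number 33.8 percentage points higher from compound 2 to compound 3 (beyond the scatter) came with (4-methoxyphenyl)carbamoyl in place of 3-methylbut-2-en-1-yl on an oxygen on an aromatic ring.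

Compound 4 `CC(C)=CCC/C(C)=C/CC1Cc2c(OC(=O)Nc3cccc(C(F)(F)F)c3)cc(=O)n(CCCO)c2CC1(C)C` differs from compound 3 by 3-(trifluoromethyl)phenyl in place of 4-methoxyphenyl on an amide-type nitrogen. Neither measured step touches the aryl group on the amide-type nitrogen: the step from compound 2 to compound 3 brought in the whole carbamoyl group, and the step from compound 1 to compound 3 altered the chain. The measurements say nothing about exchanging one aryl group for another at that place. Since compound 4 keeps both the carbamoyl group and the chain that accompany the high number of compound 3, one expects a step of a number 4.1 percentage points lower from compound 3 to compound 4 (within the scatter) that stays within the scatter. Compound 4 is estimated at 60%, in a range from 40% to 78%.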

Compound 4, a percentage reported as inhibition, at one concentration (the size of the read-out at that concentration, not a potency): 44%
Compound 4: the middle estimate sits 16 percentage points above what was measured; the range from low to high includes it.
By their numbers in this assay, from the lowest: compound 1; then compound 2; then compound 4; then compound 3.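

Going by these compounds alone, until this result, the earlier compounds had tied the number in this assay only to the carbamoyl group as a whole and to the chain, whereas this exchange on the amide-type nitrogen shows that the aryl group also counts: 3-(trifluoromethyl)phenyl in place of 4-methoxyphenyl came with a number 20.1 percentage points lower from compound 3 to compound 4 (beyond the scatter) at this place. The step is modest in size, and compound 4 still gives 44%, so the exchange lowers the inhibition at the concentration tested without abolishing it. The two names differ both in the group on the ring and in its number, so this single step does not separate the two, and nothing at hand offers a reason for the drop.

Left open is how a plain phenyl group, or a phenyl carrying a chlorine or an amine, would read on that nitrogen, and whether a saturated group such as cyclohexyl could take the place of the aryl ring at all. Also open, from the compounds shown here alone, is whether the same aryl exchange would give a similar step on the 3-methylbut-2-en-1-yl chain of compound 1 .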